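Turning a methyl group into isobutyl

The compounds below may be only part of what the source reports. "The series", "measured", "known", "first", "only" and "open" are said of these compounds alone.

Among the measured compounds shown here, in a functional assay on brain (Rattus norvegicus, strain Wistar) for inhibition (a lower number here means a stronger inhibitor, a higher number a weaker inhibitor), compound 2 (`Cc1ccc(-c2c(C)[nH]c(=O)n2C)cc1`) gives 85300 nM, the higher of the two numbers so far. Compound 1 (`CCCCc1ccc(-c2c(CC)[nH]c(=O)n2C)cc1`) gives 13900 nM, lower by more than the usual scatter. Compound 3 (`Cc1[nH]c(=O)n(C)c1-c1ccc(CC(C)C)cc1`) has isopropyl in place of hydrogen on a saturated chain carbon bound to an aromatic carbon, so methyl becomes isobutyl (isopropyl in place of hydrogen on a saturated chain carbon bound to an aromatic carbon). For the measured compounds named here, no measured pair shows this change alone, so the only guide in this assay is that compound 1 reaches 13900 nM. The expected step of a 3.4-fold lower number from compound 2 to compound 3 (0.53 log units; beyond the scatter) is moderate, towards a lower number and beyond the scatter. Compound 3 is estimated at 25000 nM, within a range of 9000 nM to 60000 nM.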

Compound 3, half-maximal inhibitory concentration: 7800 nM
Estimate against measurement, compound 3: 3.2-fold (0.51 log units) above; the measured number lies below the stated range.
By their numbers in this assay, from the lowest: compounds 3 and 1 (each within the scatter of the next); then compound 2.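

In this assay, methyl becoming isobutyl is the only difference behind an 11-fold lower number from compound 2 to compound 3 (1.04 log units; beyond the scatter), so this change alone moves the number by a large step. The earlier pair differed in more than one place and could not show what this position does by itself. Nothing measured here accounts for the size of this step.

As far as these compounds go, whether a longer chain such as hexyl, or an amine, at this place would lower the number further remains open. So does whether the same change gives a similar step on a core carrying other groups.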